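Swapping the Pendant Ring: From Compound 3 to Compound 4

The compounds below may be only part of what the source reports. "The series", "measured", "known", "first", "only" and "open" are said of these compounds alone.

Three measured compounds share one core and differ only in the ring that hangs from a saturated chain carbon bound to an aromatic carbon. In an assay on isolated protein for inhibition of Long-chain-fatty-acid--CoA ligase 1 (Mus musculus), read by mass spectrometry, with a stated time of 90 min, in the presence of a further agent that is not named here (on this read-out lower numbers stand for stronger inhibition and higher numbers for weaker inhibition), compound 1 `Cn1c(Cc2cccc(C(F)(F)F)c2)nc2cc(O[C@H]3CC[C@@H](C(=O)O)CC3)ccc21` gives 86 nM. Compound 2 `Cn1c(Cc2cccc(C#N)c2)nc2cc(O[C@H]3CC[C@@H](C(=O)O)CC3)ccc21` gives 22000 nM in this assay, which is a 260-fold higher number from compound 1 to compound 2 (2.41 log units; beyond the scatter). Compound 3 `Cn1c(Cc2cccnc2)nc2cc(O[C@H]3CC[C@@H](C(=O)O)CC3)ccc21` is recorded only as > 200000 nM in this assay, a limit rather than a number. It therefore stands at the limit of > 200000 nM in this assay, at which 1 of the 3 values shown sits, the weakest point the data can show. The moves to it were an at least 2300-fold higher number from compound 1 to compound 3 (3.36 log units; beyond the scatter) and an at least 9.0-fold higher number from compound 2 to compound 3 (0.95 log units; beyond the scatter), so replacing a carbon-only aromatic ring with a nitrogen-containing one cost a great deal each time.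

Compound 4 `Cn1c(Cc2ccc3c(c2)OCC3)nc2cc(O[C@H]3CC[C@@H](C(=O)O)CC3)ccc21` makes the reverse kind of change: a group of 9 heavy atoms (8 carbon, 1 oxygen; one five-membered non-aromatic ring with 1 hetero atom, one six-membered aromatic ring of carbon only) in place of a group of 6 heavy atoms (5 carbon, 1 nitrogen; one six-membered aromatic ring with 1 hetero atom), on a saturated chain carbon bound to an aromatic carbon. Because compound 1 with its carbon-only ring gave 86 nM and compound 2 with its carbon-only ring gave 22000 nM, the return to such a ring is expected to bring compound 4 well back inside the measurable range of this assay. Compound 4 is therefore estimated at 600 nM, somewhere between 60 nM and 20000 nM. That estimate means an expected step of an at least 330-fold lower number from compound 3 to compound 4 (2.52 log units; beyond the scatter), though its exact size remains uncertain.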

Compound 4, half-maximal inhibitory concentration: 36 nM
Compound 4: middle estimate off by 17-fold (1.22 log units), on the high side; the whole stated range lies above it.
By their numbers in this assay, from the lowest: compound 4; then compound 1; then compound 2. At a limit, above all of these: compound 3.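

The pendant position does not need a trifluoromethyl group to reach strong inhibition in this assay, since a quite different two-ring group also does so, with a 2.4-fold lower number from compound 1 to compound 4 (0.38 log units; beyond the scatter) and a 610-fold lower number from compound 2 to compound 4 (2.79 log units; beyond the scatter). A hetero atom in the pendant group is not costly in itself either: the group that enters and the pyridin-3-yl that leaves each hold one hetero atom and count one hydrogen-bond acceptor, yet the change gives an at least 5500-fold lower number from compound 3 to compound 4 (3.74 log units; beyond the scatter). That step is a minimum, and compound 3 remains a limit rather than a number: the limit of > 200000 nM in this assay, at which 1 of the 4 values shown sits.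

On these data alone, what the oxygen contributes stays open, since a group with the same two rings but a carbon in place of that oxygen, or a single benzene ring carrying a methoxy group, would be needed to separate the oxygen from the second ring. The compounds shown also leave open why the nitrile of compound 2 and the ring nitrogen of compound 3 give such weak results, and whether an amine or a longer chain at this position would be tolerated.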